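Ester Variation at the Hydroxyl and Plasma Half-Life

The source may report more compounds than this note shows. Statements on the series, on what has been measured and on what is new or still open speak of the compounds shown alone.

Compound 1 `CC(=O)Oc1ccccc1C(=O)O[C@H]1CO[C@H]2[C@@H]1OC[C@H]2O`: 0.0183 h
Compound 2 `CC(=O)Oc1ccccc1C(=O)O[C@H]1CO[C@H]2[C@@H]1OC[C@H]2OC(C)=O`: 0.0095 h
Compound 3 `CC(=O)Oc1ccccc1C(=O)O[C@H]1CO[C@H]2[C@@H]1OC[C@H]2OC(=O)C1CC1`: 0.015 h

The three compounds share one core and differ only in what sits on the oxygen on a saturated carbon, measured in an ADME assay on a cell-free system (plasma, Homo sapiens) for metabolic stability, with Plasma (Rattus norvegicus) as the target, read by HPLC, at pH 7.4; on this read-out higher numbers stand for a longer-lived compound and lower numbers for a shorter-lived compound. Compound 3 stands second highest of the three numbers: its nearest neighbour is compound 1 a 1.2-fold lower number from compound 1 to compound 3 (0.09 log units; within the scatter), its furthest compound 2 a 1.6-fold higher number from compound 2 to compound 3 (0.20 log units; within the scatter). The step between compound 1 and compound 2 is likewise within the scatter a 1.9-fold lower number from compound 1 to compound 2 (0.28 log units; within the scatter). Nothing among these three steps separates the acyl groups from one another.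

Compound 4 `CC(=O)Oc1ccccc1C(=O)O[C@H]1CO[C@H]2[C@@H]1OC[C@H]2OC(=O)c1ccc(-c2ccccc2)cc1` follows from compound 3 by one change: 4-phenylphenyl in place of cyclopropyl on a carbonyl carbon. The step bearing most directly on it is a 1.6-fold higher number from compound 2 to compound 3 (0.20 log units; within the scatter), a change of the group on the same carbonyl carbon, and it stayed within the scatter. Within the data shown here, no measured step reaches beyond the scatter, so no directional change is expected in this assay. Compound 4 is therefore estimated at 0.015 h, within 0.006 h to 0.04 h, and the expected step is no change at the digits printed from compound 3 to compound 4 (within the scatter).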

Compound 4, half-life: > 0.333 h
Compound 4: no number, only a limit; the forecaster's own chance of this, stated with the estimate: 5%; middle value at least 22-fold (1.34 log units) away from the limit.
By their numbers in this assay, from the lowest: compounds 2, 3 and 1 (each within the scatter of the next). At a limit, above all of these: compound 4.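

In this assay, the group on this carbonyl carbon proves able to move the half-life: 4-phenylphenyl in place of cyclopropyl gives an at least 22-fold higher number from compound 3 to compound 4 (1.34 log units; beyond the scatter), and 4-phenylphenyl in place of methyl gives an at least 35-fold higher number from compound 2 to compound 4 (1.54 log units; beyond the scatter), whereas every earlier step among compounds 1, 2 and 3 stayed within the scatter. Compound 4 has only a limit, > 0.333 h, not a number, so the full size of both steps stays unknown: the limit of > 0.333 h in this assay, at which 1 of the 4 values shown sits.

Among the acyl groups shown, only the one carrying 4-phenylphenyl separates from the rest at this position, so the oxygen on a saturated carbon is no longer a place where the choice of acyl group appears to make no difference.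

The compounds shown leave open whether a single phenyl on the same carbonyl carbon would already give a step of this kind or whether the second ring is needed. They also leave open how a carboxylic acid or an amine carried on that ring would read, and which ester is lost first.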